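Swapping the 4-aminobenzyl group of compound 1 for 3-methylbenzyl

The source may report more compounds than this note shows. Statements on the series, on what has been measured and on what is new or still open speak of the compounds shown alone.

Going by the values given here, only two compounds have been read so far, and neither has given a number. Compound 1 `COC(=O)c1ccc(NCc2cncn2Cc2ccc(N)cc2)cc1-c1ccccc1` gives > 10000 nM in a toxicity assay on NIH3T3 cells (Mus musculus) for cytotoxicity, read by resazurin assay (a higher number here means that more compound is needed for the effect, a lower number that less compound is needed), and this is a limit of the assay. Compound 2 `N#Cc1ccc(NCc2cncn2Cc2ccc(-c3ccccc3)cc2N)cc1-c1ccccc1` gives > 1000 nM and this too is only a limit. Among the compounds with values here, compound 1 therefore stands at a limit, with no exact value to step from.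

Compound 3 `COC(=O)c1ccc(NCc2cncn2Cc2cccc(C)c2)cc1-c1ccccc1` keeps the core of compound 1 and differs in one place. The change 3-methylphenyl in place of 4-aminophenyl on a saturated chain carbon bound to an aromatic nitrogen puts 3-methylphenyl in place of 4-aminophenyl on a saturated chain carbon bound to an aromatic nitrogen.

Within the data shown here, no measured step speaks to this change. For compound 3 the expected move is a number no higher from compound 1 to compound 3 (the limit leaves the size open) in this assay and no step beyond the scatter is expected in either direction. Compound 3 is estimated at 10000 nM with an expected range from 3000 nM to 30000 nM for the coming measurement.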

Compound 3, half-maximal effective concentration: > 10000 nM
Compound 3 gave a limit, no number; the forecaster's own chance of this, stated with the estimate: 65%; the middle value sits exactly at the limit.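

Compound 1 and compound 3 both give only a limit in this assay, so no step can be read between them: the limit of > 10000 nM in this assay, at which 2 of the 3 values shown sit.

The compounds shown leave open whether 3-methylbenzyl in place of 4-aminobenzyl changes the concentration needed for cytotoxicity at all.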